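From compound 2 to compound 3: one oxygen substituent exchanged

The compounds below may be only part of what the source reports. "The series", "measured", "known", "first", "only" and "open" are said of these compounds alone.

Measured compounds:
- compound 1 `CC(C)(O)CN1CCC(Oc2ccc([C@H]3CC[C@]4(CC3)OOC3(O4)C4CC5CC(C4)CC3C5)cc2)CC1` gives 1810 nM
- compound 2 `c1cc([C@H]2CC[C@]3(CC2)OOC2(O3)C3CC4CC(C3)CC2C4)ccc1OCC1CCNCC1` gives 465 nM

In an ADME assay on the whole organism (strain FVB) for pharmacokinetics, with Mus musculus as the target, read by LC-MS, at a dose of 30 mg/kg by the oral route (a lower number here means less compound in the circulation, a higher number more compound in the circulation at the dose given), compound 2 stands lowest of the two measured compounds. Compound 3 `CC(C)(CN)Oc1ccc([C@H]2CC[C@]3(CC2)OOC2(O3)C3CC4CC(C3)CC2C4)cc1` differs from compound 2 by one exchange (1-(aminomethyl)-1-methylethyl in place of (piperidin-4-yl)methyl on an oxygen on an aromatic ring) on an oxygen on an aromatic ring. Among the compounds with values here, the only measured step at this place (a 3.9-fold lower number from compound 1 to compound 2 (0.59 log units; beyond the scatter)) shows that a change here can move this assay beyond the scatter, but it does not involve the entering group and gives no direction. No step beyond the scatter is therefore expected (a 1.3-fold higher number from compound 2 to compound 3 (0.11 log units; within the scatter)). Compound 3 is estimated at (600 nM), with an expected range (200 nM to 1800 nM).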

Compound 3, maximal plasma concentration: 529 nM
Estimate against measurement, compound 3: 1.1-fold (0.05 log units) above; the range from low to high includes it.
By their numbers in this assay, from the lowest: compounds 2 and 3 (each within the scatter of the next); then compound 1.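

In this assay, the open-chain 1-(aminomethyl)-1-methylethyl on the oxygen on an aromatic ring reads within the scatter of the ring-bearing (piperidin-4-yl)methyl (a 1.1-fold higher number from compound 2 to compound 3 (0.06 log units; within the scatter)), so at this place a ring in the substituent is not required for this level of compound in the circulation. Compound 3 also stays beyond the scatter from the 1-(2-hydroxy-2-methylpropyl)piperidin-4-yl group (a 3.4-fold lower number from compound 1 to compound 3 (0.53 log units; beyond the scatter)), as compound 2 did. No evidence is available to explain either step. From the compounds shown here alone, whether a 2-hydroxy-2-methylpropyl group on the amine of compound 3 would raise the number remains open, as does the effect of a carboxylic acid in place of that amine.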